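Replacing an Aminomethyl-Bearing Group with Phenyl on a Carbonyl

The compounds below may be only part of what the source reports. "The series", "measured", "known", "first", "only" and "open" are said of these compounds alone.

The measured compounds so far:
Compound 1 `O=C(C1CCCCC1)N1CCC(C(=O)N2N=CCC2c2ccccc2)CC1`: in a physicochemical assay for lipophilicity, read by HPLC, measured as chromatographic lipophilicity, at pH 7.4 (on this read-out higher numbers stand for higher lipophilicity and lower numbers for lower lipophilicity), compound 1 gives 5.4.
Compound 2 `CC(C)(CN)C(=O)N1N=CCC1c1ccccc1`: in this assay compound 2 gives 1.4.
Compound 3 `CC(C)(C)C(=O)N1N=CCC1c1cccc(Cl)c1`: in this assay compound 3 gives 6.6.

Among these three numbers compound 2 stands lowest. Compound 1 lies well above it, with a gap far beyond the scatter of repeated measurements, and compound 3 lies higher still, also well beyond the scatter. Going by the values given here, none of the three compounds differs from another in only one place, so no single-point step between measured compounds is available.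

Compound 4 `O=C(c1ccccc1)N1N=CCC1c1ccccc1` has not yet been measured. Compared with compound 2, the change is this:
phenyl in place of 1-(aminomethyl)-1-methylethyl on a carbonyl carbon
The group that leaves carries one hydrogen-bond donor and one hydrogen-bond acceptor; the phenyl that enters carries none. Both measured compounds without such a donor and acceptor, compound 1 and compound 3, sit far above compound 2 in this assay.

On that basis a large upward step is expected: the estimated step of a number 3.80 log units higher from compound 2 to compound 4 (beyond the scatter) is well beyond the scatter. Compound 4 is therefore expected to reach about 5.2 in this assay, most likely between 4.4 and 6.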

Compound 4, distribution coefficient: 4.6
The estimate for compound 4 lay 0.60 log units above the measured number, and the stated range covers the measured number.
By their numbers in this assay, from the lowest: compound 2; then compound 4; then compound 1; then compound 3.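

Placing phenyl in place of 1-(aminomethyl)-1-methylethyl on a carbonyl carbon gives, in this assay, a number 3.20 log units higher from compound 2 to compound 4 (beyond the scatter), the first comparison here in which only one place changes, so this large gap belongs to that change alone. The change is a bundle, however: the group that leaves has no ring, 1 hydrogen-bond donor and 1 hydrogen-bond acceptor, while the phenyl that enters has one six-membered aromatic ring of carbon only and 0 of either, so the step belongs to the exchange as a whole and not to any single one of these features. Nothing measured here explains why the step has this size.

The compounds shown leave open how much of the step would remain with a cyclopentyl group on this carbonyl carbon, which has a ring but is not aromatic, or with a phenyl carrying an aminomethyl group, which combines the aromatic ring with the amine. From the compounds shown here alone, with a single pair, it also remains open whether the same exchange would give a step of similar size on a different core, such as the chlorine-bearing core of compound 3.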